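Methoxy on the pendant phenyl of compound 1

The source may report more compounds than this note shows. Statements on the series, on what has been measured and on what is new or still open speak of the compounds shown alone.

Measured compounds:
compound 1, `O=C(NCCCCc1ccccc1)n1c(=O)oc2ccc(-c3ccccc3)cc21`, 42 nM
compound 2, `COc1ccc(-c2ccc3c(c2)oc(=O)n3C(=O)NCCCCc2ccccc2)cc1`, 67 nM
compound 3, `O=C(NCCOCc1ccccc1)n1c(=O)oc2ccccc21`, 649 nM

Of the compounds shown here, three have been measured in an assay on HEK293 cells for inhibition of acid ceramidase (Homo sapiens), with a stated time of 10 min; on this read-out lower numbers stand for stronger inhibition and higher numbers for weaker inhibition. Compound 1 gives the lowest number of the three. Compound 2 sits closest, and the gap between compound 1 and compound 2 lies within the scatter of repeated measurements, so the two cannot be ordered. Compound 3 sits furthest away, and its gap from compound 1 is beyond the scatter; compound 3 is thus the weaker inhibitor of the two.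

The unmeasured compound 4, `COc1ccc(-c2ccc3oc(=O)n(C(=O)NCCCCc4ccccc4)c3c2)cc1`, is derived from compound 1 by a single change: methoxy in place of hydrogen on an aromatic carbon. Within the data shown here, no step between two measured compounds isolates this change, so its size cannot be read off directly. What the numbers do show is that compound 2, which also carries a 4-methoxyphenyl on the shared core, gives a value within the scatter of compound 1. On that basis the step from compound 1 to compound 4 is expected to be small, a 1.2-fold higher number from compound 1 to compound 4 (0.08 log units; within the scatter), with no change beyond the scatter in either direction. Compound 4 is therefore estimated at 50 nM in this assay, with a range of 20 nM to 130 nM.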

Compound 4, half-maximal inhibitory concentration in the acid ceramidase assay: 67 nM
The estimate for compound 4 lay 1.3-fold (0.13 log units) below the measured number, and the stated range covers the measured number.
By their numbers in the acid ceramidase assay, from the lowest: compounds 1, 2 and 4 (each within the scatter of the next); then compound 3.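

In the acid ceramidase assay, the change from phenyl to 4-methoxyphenyl can now be read directly as a single step, a 1.6-fold higher number from compound 1 to compound 4 (0.20 log units; within the scatter), so methoxy in place of hydrogen at this place, para to a large group, produces no difference that can be told from the scatter. The same change can also be read in a physicochemical assay for metabolic stability, read by HPLC, in phosphate buffer, at pH 7.4, tested at 10 uM (on this read-out higher numbers stand for a longer-lived compound and lower numbers for a shorter-lived compound), where compound 1 gives 4.93 h and compound 4 gives 2.93 h, a step of a 1.7-fold lower number from compound 1 to compound 4 (0.23 log units; within the scatter), so neither read-out separates the two compounds. Nothing among the available data offers an explanation for either result.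

Among these compounds, this single step covers only one group at one place on that ring, so it remains open whether an amine, a carboxylic acid or a longer alkoxy chain at the same place would also stay within the scatter in either read-out. Compound 3 differs from compound 1 in more than one place, so in the acid ceramidase assay compound 3 gives 649 nM and this value cannot be assigned to any one part of its structure.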